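Inverting the carbinol stereocentre of compound 1

This account rests on a few compounds, and the source may have more. Where it says the series, first, only, none or still open, it means among the compounds named here.

Measured so far in a functional assay on the whole organism (strain Hartley) for inhibition, with Cavia porcellus as the target, with stated times of 15 min and 2 min; a lower number here means that less compound is needed, a higher number that more compound is needed for the effect:
compound 1 `CCCCC1([C@@H](O)/C=C/C2[C@H](O)CC(=O)[C@@H]2CCCCCCC(=O)O)CCC1` gives 0.0439 mg/kg
compound 2 `CCCC1([C@@H](O)/C=C/C2[C@H](O)CC(=O)[C@@H]2C/C=C\CCCC(=O)O)CCC1` gives 0.265 mg/kg
compound 3 `CCCCC1([C@@H](O)/C=C/C2CCC(=O)[C@@H]2CCCCCCC(=O)O)CCC1` gives 0.0203 mg/kg

Compound 1 stands second highest of the three numbers; compound 3 is nearest, by a 2.2-fold lower number from compound 1 to compound 3 (0.33 log units; beyond the scatter), and compound 2 furthest, at the higher number. Compound 4 `CCCCC1([C@H](O)/C=C/C2[C@H](O)CC(=O)[C@@H]2CCCCCCC(=O)O)CCC1` keeps every atom and bond of compound 1: the two compounds have the same atoms and bonds; at least one stereo element is drawn with a configuration in one of them and without one in the other: 1 of 5 stereo elements differ; a stereocentre at a saturated chain carbon is drawn S in compound 1 and R in compound 4. Going by the values given here, no measured step tests an inversion of configuration. Among the compounds with values here, the single one-point step, a 2.2-fold lower number from compound 1 to compound 3 (0.33 log units; beyond the scatter), replaces the hydroxy on a saturated ring carbon with hydrogen and is modest; it gives no guide to the chain carbinol. The direction therefore cannot be read from the series, and the estimate for compound 4 is set at a higher number with a wide range, an expected step of a 5.7-fold higher number from compound 1 to compound 4 (0.76 log units; beyond the scatter). Compound 4 is expected at 0.25 mg/kg, between 0.05 mg/kg and 1.5 mg/kg.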

Compound 4, dose for half-maximal effect: 0.00126 mg/kg
Compound 4: the middle estimate sits 200-fold (2.30 log units) above what was measured, outside the stated range (below it).
By their numbers in this assay, from the lowest: compound 4; then compound 3; then compound 1; then compound 2.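

In this assay the configuration of the saturated chain carbon bearing the hydroxy proves a highly sensitive point, with no atom or bond changed: a 35-fold lower number from compound 1 to compound 4 (1.54 log units; beyond the scatter). This step shows that the drawn R configuration needs less compound than the drawn S, a direction the ring-hydroxy step gave no sign of. The reading carries one caution: the fact that one of compounds 1 and 4 is drawn with a defined configuration and the other without, at the place where they differ.

Going by these compounds, it remains open whether the R advantage holds with the unsaturated chain of compound 2 or without the ring hydroxy, as in compound 3. On these data alone, a methyl group on the carbinol carbon also remains untested here.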